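Methoxy to nitro: a change at an aromatic carbon

The source may hold more compounds than are shown below. What is called first, only, known or untested is meant among the compounds shown, and "the series" means these compounds.

Measured so far in a functional assay on MCF7 cells (Homo sapiens) for antiproliferative activity, read by WST assay, with a stated time of 72 h; on this read-out lower numbers stand for stronger inhibition and higher numbers for weaker inhibition:
- compound 1 `Clc1ccc(-c2noc(-c3cc4ccccc4[nH]3)n2)cc1`: > 50000 nM
- compound 2 `COc1ccc2[nH]c(-c3nc(-c4ccc(Cl)cc4)no3)cc2c1`: > 50000 nM

Both values are assay limits, not numbers. Compound 1 gives only the limit > 50000 nM in this assay. Compound 2 likewise gives only the limit > 50000 nM in this assay. Going by the values given here, the one measured step, methoxy in place of hydrogen on an aromatic carbon, is a step that the two limits leave unreadable from compound 1 to compound 2. So compound 2 stands at the limit, where every measured value sits (the limit of > 50000 nM in this assay, at which 2 of the 2 values shown sit).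

Compound 3 `O=[N+]([O-])c1ccc2[nH]c(-c3nc(-c4ccc(Cl)cc4)no3)cc2c1` differs from compound 2 in one place: nitro in place of methoxy on an aromatic carbon. Among the compounds with values here, the only measured step that bears on it is the one from compound 1 to compound 2, which touches the same aromatic carbon, but that step was unreadable, so it sets neither size nor direction. With no readable step in hand and both known values at the limit, no step beyond the scatter in this assay is expected. Compound 3 is therefore estimated at 50000 nM, within 10000 nM to 200000 nM, and the expected step of a number no higher from compound 2 to compound 3 (the limit leaves the size open) is essentially none, most likely ending again at the limit.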

Compound 3, half-maximal inhibitory concentration: > 50000 nM
Compound 3 was reported as a limit (the forecaster's own chance of this, stated with the estimate: 75%); the middle value lies on the limit itself.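

In this assay, compound 3 also gives only a limit, so the steps linking compounds 1, 2 and 3 cannot be read. The compounds shown leave open whether hydrogen, methoxy or nitro at this aromatic carbon makes any difference to the activity, as all three results are limits rather than numbers: the limit of > 50000 nM in this assay, at which 3 of the 3 values shown sit.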